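Removing a Chloro Group: What to Expect for Compound 4

The source may report more compounds than this note shows. Statements on the series, on what has been measured and on what is new or still open speak of the compounds shown alone.

compound 1 `Cc1cc(C)c(Nc2cc(Cl)cc(C(F)(F)F)c2)c(C)c1`: 500 nM
compound 2 `Cc1cc(C)c(Nc2ccc(Br)cc2)c(C)c1`: 1600 nM
compound 3 `Cc1cc(C)c(Nc2c(F)cc(F)cc2F)c(C)c1`: 2700 nM

In an assay on isolated protein for binding affinity to Rap guanine nucleotide exchange factor 4 (Homo sapiens), read by cAMP accumulation (on this read-out lower numbers stand for stronger inhibition and higher numbers for weaker inhibition), compound 1 gives the lowest of the three numbers. Compound 2 sits beyond the scatter from it, and compound 3 lies further still, so compound 1 is the most potent of the measured set. Compound 4 `Cc1cc(C)c(Nc2cccc(C(F)(F)F)c2)c(C)c1` differs from compound 1 by a single change: hydrogen in place of chloro on an aromatic carbon. Among the compounds with values here, no measured pair shows this exact step, so its size is open. Since the compounds lacking a chloro group, compound 2 with 1600 nM and compound 3 with 2700 nM, both give higher numbers than compound 1, a weakening step from compound 1 to compound 4 of about a 3.0-fold higher number from compound 1 to compound 4 (0.48 log units; beyond the scatter) is expected, beyond the scatter. Compound 4 is therefore expected to give 1500 nM, within 500 nM to 5000 nM.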

Compound 4, half-maximal inhibitory concentration: 2000 nM
Compound 4: the middle estimate sits 1.3-fold (0.12 log units) below what was measured, within the range that was stated.
By their numbers in this assay, from the lowest: compound 1; then compounds 2, 4 and 3 (each within the scatter of the next).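

With the chloro group meta to a trifluoromethyl group as the only difference, this assay now gives this position a step of its own: hydrogen in place of chloro brings a 4.0-fold higher number from compound 1 to compound 4 (0.60 log units; beyond the scatter) and so a modest loss that lies beyond the scatter. The earlier compounds shown here differed in more than one place and could not single this change out. Nothing in the data at hand accounts for the step. As far as these compounds go, whether an amine, a methoxy group or a nitrile at this carbon would match chloro stays open, as does the size of this step in compounds without the trifluoromethyl group.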